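The source may report more compounds than this note shows. Statements on the series, on what has been measured and on what is new or still open speak of the compounds shown alone.

Compound 1 `CC1=C(C(=O)Nc2ccc(F)cc2)C(c2ccc([N+](=O)[O-])cc2)N=C(SCc2ccc(F)cc2)N1`: 25.6%
Compound 2 `CC1=C(C(=O)Nc2ccc([N+](=O)[O-])cc2)C(c2ccc(Br)cc2)N=C(SCc2ccccc2Cl)N1`: 15.4%

In a functional assay on the whole organism (artery, strain albino) with Rattus norvegicus as the target, with a stated time of 240 min, at a dose of 10 mg/kg by the oral route (a higher number here means more inhibition at the dose given (going by the name of the read-out), a lower number less inhibition), compound 2 stands lowest of the two measured compounds, and compound 1 sits higher by a margin beyond the usual scatter. Compound 3 `CC1=C(C(=O)Nc2ccc([N+](=O)[O-])cc2)C(c2ccc(Br)cc2)N=C(SCc2ccc(F)cc2)N1` differs from compound 2 in one place: 4-fluorophenyl in place of 2-chlorophenyl on a saturated chain carbon bound to a sulfur. Among the measured compounds shown here, no pair of measured compounds isolates this change, so there is no measured step to lean on, and a small shift in either direction, or none beyond the scatter, is expected. The estimate for compound 3 in this assay is 20% (8% to 35%), a step of a number 4.6 percentage points higher from compound 2 to compound 3 (within the scatter) that is expected to stay within the scatter.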

Compound 3, a percentage reported as inhibition, in the whole organism at one dose (the size of the read-out at that dose, not a potency): 27.2%
Compound 3: the middle estimate sits 7.2 percentage points below what was measured; the measured number falls inside the stated range.
By their numbers in this assay, from the lowest: compound 2; then compounds 1 and 3 (each within the scatter of the next).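

In this assay, among the compounds shown here, the swap of 2-chlorophenyl for 4-fluorophenyl on a saturated chain carbon bound to a sulfur gives a number 11.8 percentage points higher from compound 2 to compound 3 (beyond the scatter) and is the first comparison to isolate this position, with the rest of the molecule unchanged. The step is modest, but it shows that the number can move with this group alone. No measured evidence explains the shift.

The halogen and its place on the ring change together, so 4-chlorophenyl or 2-fluorophenyl would be needed to separate the two. From the compounds shown here alone, how an amine or a carboxylic acid at this position would behave also remains open.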